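Shifting a trifluoromethyl group around the benzyl ring

This account rests on a few compounds, and the source may have more. Where it says the series, first, only, none or still open, it means among the compounds named here.

Compound 1 `CC(C)(N)C(=O)N[C@H](COCc1ccc(F)cc1F)c1nnnn1CCOC(=O)NCCCCO`: 0.42 nM
Compound 2 `CC(C)(N)C(=O)N[C@H](COCc1ccccc1Cl)c1nnnn1CCOC(=O)NCCCCO`: 0.45 nM
Compound 3 `CC(C)(N)C(=O)N[C@H](COCc1ccccc1C(F)(F)F)c1nnnn1CCOC(=O)NCCCCO`: 0.72 nM

In a functional assay on cells for inhibition of growth hormone secretagogue receptor type 1 (Homo sapiens), read by FLIPR and calcium flux (a higher number here means that more compound is needed for the effect, a lower number that less compound is needed), compound 1 gives the lowest of the three numbers, yet both a 1.1-fold higher number from compound 1 to compound 2 (0.03 log units; within the scatter) and a 1.7-fold higher number from compound 1 to compound 3 (0.23 log units; within the scatter) lie within the scatter, so the three compounds cannot be told apart. Compound 4 `CC(C)(N)C(=O)N[C@H](COCc1cccc(C(F)(F)F)c1)c1nnnn1CCOC(=O)NCCCCO` is not yet measured; it differs from compound 1 by 3-(trifluoromethyl)phenyl in place of 2,4-difluorophenyl on a saturated chain carbon bound to an oxygen on a saturated carbon. The step that bears on it is a 1.7-fold higher number from compound 1 to compound 3 (0.23 log units; within the scatter), where a trifluoromethyl group also enters the benzyl ring without moving the number beyond the scatter; the step of a 1.6-fold higher number from compound 2 to compound 3 (0.20 log units; within the scatter) points the same way. Among the measured compounds shown here, no measured step tests this particular position of the group. Compound 4 is therefore expected to stay close, a 1.7-fold higher number from compound 1 to compound 4 (0.22 log units; within the scatter), with an estimated 0.7 nM and a range of 0.3 nM to 2 nM.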

Compound 4, half-maximal effective concentration: 1.79 nM
Compound 4: middle estimate off by 2.6-fold (0.41 log units), on the low side; the measured number falls inside the stated range.
By their numbers in this assay, from the lowest: compounds 1, 2 and 3 (each within the scatter of the next); then compound 4.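

In this assay, taking 3-(trifluoromethyl)phenyl in place of 2-(trifluoromethyl)phenyl gives a 2.5-fold higher number from compound 3 to compound 4 (0.40 log units; beyond the scatter) and so shows that the place of the trifluoromethyl group on the benzyl ring matters, although all earlier steps lay within the scatter. The same group also separates compound 4 from the other two compounds, with a 4.3-fold higher number from compound 1 to compound 4 (0.63 log units; beyond the scatter) and a 4.0-fold higher number from compound 2 to compound 4 (0.60 log units; beyond the scatter) both beyond the scatter. Nothing available explains this shift. The compounds shown leave open whether a nitrile or a methoxy group in place of the trifluoromethyl on the 3-(trifluoromethyl)phenyl would behave the same way.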